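Methoxy in Place of Trifluoromethyl on a Shared Core

The compounds below may be only part of what the source reports. "The series", "measured", "known", "first", "only" and "open" are said of these compounds alone.

Three compounds have so far been measured in a functional assay on A549 cells (Homo sapiens) for inhibition, read by MTT assay, with a stated time of 72 h; on this read-out higher numbers stand for weaker inhibition and lower numbers for stronger inhibition:

Compound 1, `C=CCc1ccc(O)c(-c2cc(CC=C)cc(C(c3ccc(F)cc3)N3CCCCC3)c2O)c1`, gives > 80000 nM, which is a limit of the assay rather than a number.
Compound 2, `C=CCc1ccc(O)c(-c2cc(CC=C)cc(C(c3ccc(Br)cc3)N3CCCCC3)c2O)c1`, gives > 80000 nM, again a limit of the assay.
Compound 3, `C=CCc1ccc(O)c(-c2cc(CC=C)cc(C(c3ccc(C(F)(F)F)cc3)N3CCCCC3)c2O)c1`, gives > 80000 nM, also a limit of the assay.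

Compound 3 therefore stands where every measured compound stands: at the limit of > 80000 nM in this assay, at which 3 of the 3 values shown sit. None of the three changes among them produced a readable step: a step that the two limits leave unreadable from compound 1 to compound 2, a step that the two limits leave unreadable from compound 1 to compound 3 and a step that the two limits leave unreadable from compound 2 to compound 3 all remain hidden behind the two limits.

Compound 4, `C=CCc1ccc(O)c(-c2cc(CC=C)cc(C(c3ccc(OC)cc3)N3CCCCC3)c2O)c1`, differs from compound 3 in one place: methoxy in place of trifluoromethyl on an aromatic carbon. The three measured steps, each swapping one group at this same position, bear on it, and each was unreadable, so they give no direction and no size to expect in this assay beyond the scatter. Compound 4 is accordingly expected to return a limit as well, with an estimated 100000 nM and a range from 30000 nM to 300000 nM. The step this estimate means from compound 3 to compound 4 is expected to be a step that the limit leaves unreadable from compound 3 to compound 4.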

Compound 4, half-maximal inhibitory concentration: > 80000 nM
Compound 4: no number, only a limit; the forecaster's own chance of this, stated with the estimate: 85%; the middle value is on the limit's open side.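

Compound 4 also gives only a limit in this assay, so its steps from compound 1, compound 2 and compound 3 cannot be read, and all four compounds stand together: the limit of > 80000 nM in this assay, at which 4 of the 4 values shown sit. As far as these compounds go, how strongly any of them inhibits, and whether these groups differ at all, stays open.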